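Replacing the 2,5-dimethoxyphenyl group of compound 2

A few compounds are considered here, and "the series" means these few. Any claim that something is new, unique, unknown or untested is made for them only; others in the source may bear on it.

Going by the values given here, in an ADME assay on DU-145 cells (Homo sapiens) for cytotoxicity, read by MTT assay, with a stated time of 72 h (on this read-out lower numbers stand for stronger inhibition and higher numbers for weaker inhibition), compound 2 `COc1ccc(OC)c(C2=C(c3cc(OC)c(OC)c(OC)c3)C(=O)CC2O[SiH2]C(C)(C)C)c1` gives 100 ug/mL, the only actual number so far. Compound 1 `COc1ccc(C2=C(c3cc(OC)c(OC)c(OC)c3)C(=O)CC2O[SiH2]C(C)(C)C)cc1` stands at > 100 ug/mL, which is a limit of this assay. Compound 3 `COC(=O)c1cc(C2=C(c3cc(OC)c(OC)c(OC)c3)C(=O)CC2O[SiH2]C(C)(C)C)ccc1OC` carries the change (4-methoxy-3-(methoxycarbonyl)phenyl in place of 2,5-dimethoxyphenyl on a double-bonded ring carbon). Among the compounds with values here, the one measured step that bears on this change, a number no higher from compound 1 to compound 2 (the limit leaves the size open), also exchanges the group on a double-bonded ring carbon, but its size cannot be read. No step beyond the usual scatter is therefore expected, and no direction can be favoured. The expected step is no change at the digits printed from compound 2 to compound 3 (within the scatter). For compound 3 the estimated value is 100 ug/mL, within an expected range of 50 ug/mL to 200 ug/mL.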

Compound 3, half-maximal inhibitory concentration: > 100 ug/mL
Compound 3 was reported as a limit; the forecaster's own chance of this, stated with the estimate: 50%; the middle value sits exactly at the limit.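

In this assay, the change to 4-methoxy-3-(methoxycarbonyl)phenyl on the double-bonded ring carbon gives a number no lower from compound 2 to compound 3 (the limit leaves the size open), so adding methoxycarbonyl brought no measurable gain at this position. The value of compound 3 is a limit, and neither the size of this step nor the step between compound 1 and compound 3 can be read. The series now sits largely at one edge of the scale: the limit of > 100 ug/mL in this assay, at which 2 of the 3 values shown sit.

On these data alone, it remains open whether a carboxylic acid or an amine in place of the methoxycarbonyl would give a number clear of this limit.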